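The compounds below may be only part of what the source reports. "The series", "measured", "known", "first", "only" and "open" are said of these compounds alone.

Measured in a functional assay on the whole organism (strain Wistar) for inhibition, with Rattus norvegicus as the target, read by paw edema, with a stated time of 2 h, at a dose of 100 mg/kg; on this read-out lower numbers stand for less inhibition and higher numbers for more inhibition at the one dose given (going by the name of the read-out):

compound 1 `COc1cc2c(cc1OC)C(CC(=O)Nc1cccc(Cl)c1)CC2`: 28%
compound 2 `COc1cc2c(cc1OC)C(CC(=O)Nc1ccc(Cl)cc1)CC2`: 63%
compound 3 `COc1cc2c(cc1OC)C(CC(=O)Nc1ccc([N+](=O)[O-])cc1)CC2`: 36%

Compound 2 stands highest of the three numbers in this assay; its nearest neighbour is compound 3 and its furthest is compound 1, both beyond the scatter. The two steps around it run in one direction: a number 35 percentage points higher from compound 1 to compound 2 (beyond the scatter), so that moving the chlorine on the ring raises the number, and a number 27 percentage points lower from compound 2 to compound 3 (beyond the scatter), so that exchanging the chlorine for a nitro lowers it again. Compound 1 and compound 3 lie within the scatter of each other.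

Compound 4 `COc1cc2c(cc1OC)C(CC(=O)Nc1cccnc1)CC2` is the next member. Its difference from compound 2 is pyridin-3-yl in place of 4-chlorophenyl on an amide-type nitrogen. Going by the values given here, no measured step makes this exact change; the nearest ones are the two around compound 2, which show that any departure from the 4-chlorophenyl group has so far cost a modest to large amount. The expectation for compound 4 is therefore a lowering step, a number 28 percentage points lower from compound 2 to compound 4 (beyond the scatter), with wide uncertainty. Compound 4 is estimated at 35%, within 15% to 55%.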

Compound 4, a percentage reported as inhibition, in the whole organism at one dose (the size of the read-out at that dose, not a potency): 30%
The estimate for compound 4 lay 5 percentage points above the measured number; the measured number falls inside the stated range.
By their numbers in this assay, from the lowest: compounds 1, 4 and 3 (each within the scatter of the next); then compound 2.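

In this assay, going by these compounds alone, the earlier steps changed only the substituent on a benzene-type aryl group, whereas compound 4 replaces that aryl group with a six-membered aromatic ring holding one hetero atom, and a number 33 percentage points lower from compound 2 to compound 4 (beyond the scatter). This extends the loss seen around compound 2 to a change of the ring itself, so all three departures from 4-chlorophenyl on the amide-type nitrogen give lower numbers, and none goes against this among the four compounds. The other step, a number 2 percentage points higher from compound 1 to compound 4 (within the scatter), leaves pyridin-3-yl and 3-chlorophenyl indistinguishable at this place, and no measurement available bears on what lies behind either step.

Open, on these data alone, is whether the number of compound 2 depends on the chlorine itself, which a 4-fluorophenyl, 4-methylphenyl or unsubstituted phenyl group would test. Also open, as far as these compounds go, is whether pyridin-4-yl would behave like pyridin-3-yl.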